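This account rests on a few compounds, and the source may have more. Where it says the series, first, only, none or still open, it means among the compounds named here.

Measured in an ADME assay on the whole organism (plasma, strain 129/SvEvBrd x C57BL/6) for pharmacokinetics, with Mus musculus as the target, at a dose of 10 mg/kg by the oral route; on this read-out lower numbers stand for lower exposure and higher numbers for higher exposure at the dose given:
- compound 1 `CC(=O)c1nc([C@@H](O)[C@H](O)[C@H](O)CO)c(C)[nH]1` gives 2640 ng.h/mL
- compound 2 `CCc1[nH]c(C(C)=O)nc1[C@@H](O)[C@H](O)[C@H](O)CO` gives 1650 ng.h/mL
- compound 3 `CC(F)(F)c1nc([C@@H](O)[C@H](O)[C@H](O)CO)c[nH]1` gives 1190 ng.h/mL

Compound 3 at 1190 ng.h/mL lies within the scatter of compound 2 at 1650 ng.h/mL, while compound 1 at 2640 ng.h/mL gives a higher number, beyond the scatter.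

The next step leads to compound 4 `OC[C@@H](O)[C@@H](O)[C@H](O)c1c[nH]c(-c2ncon2)n1`, with 1,2,4-oxadiazol-3-yl in place of 1,1-difluoroethyl on an aromatic carbon.

Among the compounds with values here, only one measured step differs in a single place, a 1.6-fold lower number from compound 1 to compound 2 (0.20 log units; within the scatter), and it concerns methyl in place of hydrogen on a saturated chain carbon bound to an aromatic carbon. It does not involve either group in the present exchange, so it gives no direct size or direction. Within the data shown here, it shows only that one small change stayed within the scatter in this assay.

Among the measured compounds shown here, with no measured step for this exchange, the expectation rests on the narrow spread of the series, from compound 3 at 1190 ng.h/mL to compound 1 at 2640 ng.h/mL. No step beyond the scatter is expected, and no direction is favoured. The expected change is a 1.1-fold higher number from compound 3 to compound 4 (0.04 log units; within the scatter) and remains uncertain.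

The estimate for compound 4 is 1300 ng.h/mL, with an expected range from 350 ng.h/mL to 4000 ng.h/mL.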

Compound 4, area under the concentration-time curve: 820 ng.h/mL
Compound 4: the middle estimate sits 1.6-fold (0.20 log units) above what was measured; the measured number falls inside the stated range.
By their numbers in this assay, from the lowest: compounds 4, 3, 2 and 1 (each within the scatter of the next, the first and the last beyond it).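

At the aromatic carbon between two ring nitrogen atoms, 1,2,4-oxadiazol-3-yl in place of 1,1-difluoroethyl gives a 1.5-fold lower number from compound 3 to compound 4 (0.16 log units; within the scatter) in this assay, the first single-place step shown at this position; the earlier step, a 1.6-fold lower number from compound 1 to compound 2 (0.20 log units; within the scatter), concerned methyl in place of hydrogen on a saturated chain carbon. The exchange replaces an open group of 4 heavy atoms and no hydrogen-bond acceptors with a five-membered aromatic ring with 3 hetero atoms and 3 hydrogen-bond acceptors, yet the pair remains within the scatter, so this read-out does not separate the two groups on the shared core. No measurement shown bears on the reason for this result.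

Open, going by these compounds, is whether an amine, a nitrile or a longer chain at this aromatic carbon would also stay within the scatter of compound 3 at 1190 ng.h/mL in this assay, or would give a step beyond it. Also open, on these data alone, is whether 1,2,4-oxadiazol-3-yl in place of the acetyl group of compound 1 would give a step of similar size on that more substituted core.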